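The source may report more compounds than this note shows. Statements on the series, on what has been measured and on what is new or still open speak of the compounds shown alone.

Measured so far:
compound 1 `Brc1ccc(OCCOc2nc3ccccc3s2)cc1` — 94.6%
compound 2 `Clc1ccc(OCCOc2nc3ccccc3s2)c(Cl)c1` — 85.4%

In a functional assay on the whole organism with Mus musculus as the target, with a stated time of 1 h, at a dose of 100 mg/kg by the intraperitoneal route (on this read-out lower numbers stand for less inhibition and higher numbers for more inhibition at the one dose given (going by the name of the read-out)), compound 2 stands within the scatter of compound 1, so the two numbers shown are not set apart from each other. Compound 3 `Clc1ccc(OCCOc2nc3ccccc3s2)cc1` is not yet measured. Against compound 2 the change is hydrogen in place of chloro on an aromatic carbon. Among the measured compounds shown here, no step between two measured compounds is at hand, so the size of this change is not known from the series itself; given that compounds 1 and 2 both give high inhibition, a step no larger than the scatter, in either direction, is expected. For compound 3 an inhibition of 90% is estimated, with a range from 75% to 98%. The expected step is a number 4.6 percentage points higher from compound 2 to compound 3 (within the scatter).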

Compound 3, a percentage reported as inhibition, in the whole organism at one dose (the size of the read-out at that dose, not a potency): 66.3%
The estimate for compound 3 lay 23.7 percentage points above the measured number, and the stated range ends above it.
By their numbers in this assay, from the lowest: compound 3; then compounds 2 and 1 (each within the scatter of the next).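

In this assay this aromatic carbon, ortho to a large group, is not indifferent to its substituent: hydrogen in place of chloro gives a number 19.1 percentage points lower from compound 2 to compound 3 (beyond the scatter) and so the second chloro carries weight in this pair. The identity of the halogen also counts, as chloro in place of bromo on an aromatic carbon gives a number 28.3 percentage points lower from compound 1 to compound 3 (beyond the scatter) with the rest of the structure unchanged. No data at hand explain either step.

Open, as far as these compounds go, is how a methoxy group or an amine would fare on this aromatic carbon, and whether a longer chain would keep the inhibition.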